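Ester to primary amide across two aryl amide cores

The source may hold more compounds than are shown below. What is called first, only, known or untested is meant among the compounds shown, and "the series" means these compounds.

Compound 1 `COC(=O)c1cccc(NC(=O)c2cccc3ccccc23)c1` and compound 2 `COC(=O)c1cccc(NC(=O)c2cc3cc([N+](=O)[O-])ccc3s2)c1` both carry a methoxycarbonyl group on the shared amide-linked ring, but the difference between the two cores is not broken down here. In a physicochemical assay for solubility (on this read-out lower numbers stand for lower solubility and higher numbers for higher solubility), compound 2 gives 25 ug/mL. For compound 1 only a limit is recorded in this assay, namely < 5 ug/mL (the limit of < 5 ug/mL in this assay, at which 1 of the 3 values shown sits). Compound 3 `NC(=O)c1cccc(NC(=O)c2cc3cc([N+](=O)[O-])ccc3s2)c1` differs from compound 2 by amino in place of methoxy on a carbonyl carbon, and in this assay compound 3 gives 25 ug/mL, the step being no change at the digits printed from compound 2 to compound 3 (within the scatter). Compound 4 `NC(=O)c1cccc(NC(=O)c2cccc3ccccc23)c1` stands to compound 1 as compound 3 stands to compound 2, through the same change amino in place of methoxy on a carbonyl carbon at the same place. Because no change at the digits printed from compound 2 to compound 3 (within the scatter) left the reading of compound 2 essentially unmoved, a step near zero is expected, a number no lower from compound 1 to compound 4 (the limit leaves the size open). Compound 4 is therefore expected near 5 ug/mL, between 1.5 ug/mL and 15 ug/mL, with a fair chance that this assay again reports only a limit.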

Compound 4, solubility: 10 ug/mL
Compound 4: the middle estimate sits 2.0-fold (0.30 log units) below what was measured; the measured number falls inside the stated range.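

The change from methoxycarbonyl to carbamoyl reads an at least 2.0-fold higher number from compound 1 to compound 4 (0.30 log units; that floor lies within the scatter) in this assay, against no change at the digits printed from compound 2 to compound 3 (within the scatter) on the other core. On these two cores, the change gives no lower number in either case, but this does not show that its size carries from one core to the other. As far as these compounds go, compound 1 gives < 5 ug/mL, which is a limit and not a number, so the size of the first step stays open.

The compounds shown leave open how the change reads on any further core. They also leave open how a carboxylic acid or an amine in place of the methoxycarbonyl group would read on either core.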